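The source may hold more compounds than are shown below. What is called first, only, known or untested is meant among the compounds shown, and "the series" means these compounds.

Measured compounds in a functional assay on SK-BR-3 cells (Homo sapiens) for antiproliferative activity, read by MTT assay, with a stated time of 72 h; a lower number here means a stronger inhibitor, a higher number a weaker inhibitor:
- compound 1 `CCN1CCN(c2cc(C)c3cc(NC(=O)c4cccc(Cl)c4)ccc3n2)CC1`: 17800 nM
- compound 2 `Cc1cc(NCCN2CCN(C)CC2)nc2ccc(NC(=O)c3ccc(Cl)c(Cl)c3)cc12`: 2690 nM
- compound 3 `Cc1cc(NCCN2CCCCC2)nc2ccc(NC(=O)c3ccc(Cl)c(Cl)c3)cc12`: 1800 nM

Compound 1 gives the highest number of the three in this assay; compound 2 lies well below it, beyond the scatter, and compound 3 lower still. Among the compounds with values here, the one step measured within the set, a 1.5-fold lower number from compound 2 to compound 3 (0.17 log units; within the scatter), concerns the amine end of the molecule and stays within the scatter.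

Compound 4 `CCN1CCN(c2cc(C)c3cc(NC(=O)c4ccc(OC)cc4)ccc3n2)CC1` is the next compound for this assay. Relative to compound 1 the change is 4-methoxyphenyl in place of 3-chlorophenyl on a carbonyl carbon. Within the data shown here, no measured step touches the aryl group on the carbonyl carbon, so the size of this move has no direct precedent in the set; compounds 2 and 3 carry a different aryl group but also a different core, so their values cannot be read as a step for this change. The expectation is therefore centred near compound 1, with a wide range and a real chance that the number lands at the upper limit of this assay. For compound 4 a value of about 25000 nM is estimated, between 8000 nM and 80000 nM, which as a step is expected to be a 1.4-fold higher number from compound 1 to compound 4 (0.15 log units; within the scatter).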

Compound 4, half-maximal inhibitory concentration: 9000 nM
Estimate against measurement, compound 4: 2.8-fold (0.44 log units) above; the range from low to high includes it.
By their numbers in this assay, from the lowest: compounds 3 and 2 (each within the scatter of the next); then compounds 4 and 1 (each within the scatter of the next).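

In this assay, the first measured replacement of the aryl group on a carbonyl carbon, 4-methoxyphenyl in place of 3-chlorophenyl, gives a 2.0-fold lower number from compound 1 to compound 4 (0.30 log units; within the scatter) and so does not separate the two compounds. The replacement alters both the substituent and its place on the ring, so this single pair cannot assign any share of the step to either. No measurement in hand bears on the comparison of these two aryl groups.

A pairing of 3-methoxyphenyl or 4-chlorophenyl with the core of compound 1 would separate the substituent from its place on the ring. On these data alone, how an aryl group bearing an amine or a carboxylic acid would read on that same core remains open.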